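Trimming the amide substituent in an indole-bearing analogue

The source may report more compounds than this note shows. Statements on the series, on what has been measured and on what is new or still open speak of the compounds shown alone.

Compound 3 `CC[C@@H]1C(=O)N(C)c2cnc(-n3ccc4cc(C(=O)NC(C)C)ccc43)nc2N1C1CCCC1` carries an isopropylcarbamoyl group where compound 1 `CCCNS(=O)(=O)c1ccc(Nc2ncc3c(n2)N(C2CCCC2)[C@H](CC)C(=O)N3C)cc1` and compound 2 `CC[C@@H]1C(=O)N(C)c2cnc(Nc3ccc(S(=O)(=O)NCCO)cc3)nc2N1C1CCCC1` carry sulfonamides. In a functional assay on K562 cells (Homo sapiens) for antiproliferative activity, read by CCK-8 assay, with a stated time of 72 h (on this read-out lower numbers stand for stronger inhibition of growth and higher numbers for weaker inhibition of growth), compound 3 gives 786 nM, the highest of the three numbers, although its gaps to compound 1 and to compound 2 both stay within the scatter. Compound 1 gives 548 nM in this assay, and compound 2 gives 546 nM. Among the measured compounds shown here, the only step among the measured compounds, a 1.0-fold lower number from compound 1 to compound 2 (0.00 log units; within the scatter), concerns the sulfonamide side chain rather than an amide nitrogen, so it offers no direct guidance here; it shows only that a small change on a chain left the number unmoved.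

Compound 4 `CC[C@@H]1C(=O)N(C)c2cnc(-n3ccc4cc(C(=O)NC)ccc43)nc2N1C1CCCC1` differs from compound 3 by methyl in place of isopropyl on an amide-type nitrogen. For the measured compounds named here, no measured pair shows methyl in place of isopropyl on an amide-type nitrogen, and the single step available produced no shift. The expectation is therefore that compound 4 sits close to compound 3 in this assay, with a 1.1-fold higher number from compound 3 to compound 4 (0.03 log units; within the scatter) not reaching beyond the scatter. The estimate for compound 4 in this assay is 850 nM, with a range from 380 nM to 1900 nM.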

Compound 4, concentration for 50% growth inhibition: 705 nM
The estimate for compound 4 lay 1.2-fold (0.08 log units) above the measured number, and the stated range covers the measured number.
By their numbers in this assay, from the lowest: compounds 2, 1, 4 and 3 (each within the scatter of the next).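

In this assay, among the compounds shown here, methyl in place of isopropyl on the amide-type nitrogen gives a 1.1-fold lower number from compound 3 to compound 4 (0.05 log units; within the scatter), the first direct reading at this position, as the earlier step concerned only the sulfonamide side chain. It shows that, between these two compounds, the isopropylcarbamoyl group can give way to the methylcarbamoyl group with the numbers remaining within the scatter of each other, so this pair gives no sign that the size of this substituent matters over the range from isopropyl to methyl. Nothing available explains this result or links it to any measured property of either group.

The compounds shown leave open whether any substituent on this amide nitrogen can separate the numbers beyond the scatter, since isopropyl and methyl are the only two compared here, and a longer chain such as n-butyl, a benzyl group or a chain ending in a dimethylamino group could read differently. Going by these compounds, it also remains open how a carboxylic acid in place of the whole carbamoyl group would read in this assay.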